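Replacing furan-2-yl with 2,6-dichlorophenyl on the saturated ring carbon

The source may hold more compounds than are shown below. What is called first, only, known or untested is meant among the compounds shown, and "the series" means these compounds.

This account follows a pair of pyrazoline-type nitrate esters sharing a common core. In a functional assay on the whole organism (strain albino) for inhibition, with Rattus norvegicus as the target, read by paw edema, with stated times of 30 min and 2 h, at a dose of 100 mg/kg by the oral route (a lower number here means less inhibition, a higher number more inhibition at the dose given (going by the name of the read-out)), compound 1 `COc1ccc(C2=NN(C(=O)CO[N+](=O)[O-])C(c3c(Cl)cccc3Cl)C2)cc1OC` gives 49%, and compound 2 `COc1ccc(C2=NN(C(=O)C(C)O[N+](=O)[O-])C(c3ccco3)C2)cc1OC` gives 39%. Compound 2 stands alongside compound 1, its number lying within the usual scatter of that of compound 1, so no ordering between the two can be read from these figures. The unmeasured compound 3 `COc1ccc(C2=NN(C(=O)C(C)O[N+](=O)[O-])C(c3c(Cl)cccc3Cl)C2)cc1OC` differs from compound 2 by a single change: 2,6-dichlorophenyl in place of furan-2-yl on a saturated ring carbon. The same 2,6-dichlorophenyl group is present in compound 1, whose value of 49% sits within the scatter of compound 2. For the measured compounds named here, no step between measured compounds is available here, so the expected change is one of none beyond the scatter. The step from compound 2 to compound 3 is therefore estimated at a number 6 percentage points higher from compound 2 to compound 3 (within the scatter). Compound 3 is expected to give 45% in this assay, within a range of 30% to 60%.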

Compound 3, a percentage reported as inhibition, in the whole organism at one dose (the size of the read-out at that dose, not a potency): 53%
The estimate for compound 3 lay 8 percentage points below the measured number; the measured number falls inside the stated range.
By their numbers in this assay, from the lowest: compounds 2, 1 and 3 (each within the scatter of the next, the first and the last beyond it).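

In this assay, for the compounds shown here, the exchange of furan-2-yl for 2,6-dichlorophenyl on the saturated ring carbon gives a number 14 percentage points higher from compound 2 to compound 3 (beyond the scatter), the first step at this position, and with the rest of the structure held constant it shows that the group here can shift the read-out. The other single change, methyl in place of hydrogen on the saturated chain carbon bound to a carbonyl carbon, gives a number 4 percentage points higher from compound 1 to compound 3 (within the scatter), so with 2,6-dichlorophenyl present this methyl has no effect that can be told from the scatter. Nothing at hand bears on why the 2,6-dichlorophenyl compound reads higher.

The compounds shown leave open whether plain phenyl or a single chlorine on the phenyl would match 2,6-dichlorophenyl. They also leave open whether the methyl step would hold with furan-2-yl in place, and what an ethyl group on that chain carbon would give.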